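Pyridin-2-yl to propyl on the triazole series

The source may report more compounds than this note shows. Statements on the series, on what has been measured and on what is new or still open speak of the compounds shown alone.

Values measured in a functional assay on HeLa cells (Homo sapiens) for antiproliferative activity, read by sulforhodamine B assay, with a stated time of 48 h (on this read-out lower numbers stand for stronger inhibition of growth and higher numbers for weaker inhibition of growth), are as follows
- Compound 1 (`COc1ccc2cc(-c3cn(CCCN4C(=O)COc5ccccc54)nn3)ccc2c1`) gives > 100000 nM as a limit of the assay, not a number
- Compound 2 (`O=C1COc2ccccc2N1CCCn1cc(-c2ccccn2)nn1`) gives 10000 nM as a number
- Compound 3 (`CCCCc1cn(CCCN2C(=O)COc3ccccc32)nn1`) gives 1020 nM as a number

Compound 2 holds the higher of the two actual numbers, with compound 3 as its nearest neighbour. Compound 4 (`CCCc1cn(CCCN2C(=O)COc3ccccc32)nn1`) has not yet been measured. It carries propyl in place of pyridin-2-yl on an aromatic carbon. Within the data shown here, the one measured step bearing on this is a 9.8-fold lower number from compound 2 to compound 3 (0.99 log units; beyond the scatter) and it puts butyl in place of the same pyridin-2-yl on the same aromatic carbon. Among the measured compounds shown here, the two changes differ only in butyl against propyl, and no measured step compares those two groups. A step of similar size toward a lower number is therefore expected in this assay with compound 3 at 1020 nM as the anchor. The expected step is a 6.7-fold lower number from compound 2 to compound 4 (0.82 log units; beyond the scatter) in size. The estimate for compound 4 is 1500 nM (expected range 500 nM to 5000 nM).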

Compound 4, concentration for 50% growth inhibition: 23200 nM
The estimate for compound 4 lay 15-fold (1.19 log units) below the measured number, and the stated range ends below it.
By their numbers in this assay, from the lowest: compound 3; then compound 2; then compound 4. At a limit, above all of these: compound 1.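

In this assay, replacing pyridin-2-yl with an open chain at this aromatic carbon does not shift the number in one direction: propyl gives a 2.3-fold higher number from compound 2 to compound 4 (0.37 log units; beyond the scatter) while butyl moved the other way. The length of the chain therefore matters at this position, and shortening butyl to propyl, the change of hydrogen in place of methyl on the saturated chain carbon, gives a 23-fold higher number from compound 3 to compound 4 (1.36 log units; beyond the scatter) and reverses the gain over pyridin-2-yl. Nothing at hand gives a reason for this sharp dependence on chain length.

With only propyl and butyl as the chains shown, it remains open whether pentyl or hexyl would lower the number further or whether butyl is already near the best length. Also open, from the compounds shown here alone, is whether a branched chain such as isobutyl, or a butyl chain ending in an amine, would keep the value of compound 3.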